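Fluorination of the anilide ring in a catechol-ether amide series

The source may report more compounds than this note shows. Statements on the series, on what has been measured and on what is new or still open speak of the compounds shown alone.

Compound 1 `COc1ccc(C(=O)Nc2ccccc2F)cc1OC1CCCC1` gives 10700 nM in an assay on isolated protein for inhibition of phosphodiesterase 4A (Sus scrofa); a higher number here means a weaker inhibitor, a lower number a stronger inhibitor. Compound 2 `COc1ccc(C(=O)Nc2c(F)cccc2F)cc1OC1CCCC1` gives 70 nM in this assay, so the change fluoro in place of hydrogen on an aromatic carbon produced a 150-fold lower number from compound 1 to compound 2 (2.18 log units; beyond the scatter). Compound 3 `COc1ccc(C(=O)Nc2c(F)cnc(F)c2F)cc1OC1CCCC1` gives 85 nM in this assay; compound 2 and compound 3 lie within the scatter of each other, while compound 1 stands far from both. How the core of compound 3 differs from the core of compound 1 is not broken down here.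

Compound 4 `COc1ccc(C(=O)Nc2c(F)c(F)nc(F)c2F)cc1OC1CCCC1` carries the change (fluoro in place of hydrogen on an aromatic carbon). This is the same kind of change as from compound 1 to compound 2, not the same: there the entering fluoro sat on a six-membered aromatic ring of carbon only, ortho to a large group and meta to a fluoro group; here it sits on a six-membered aromatic ring with 1 nitrogen, next to the ring nitrogen, ortho, meta and para to fluoro groups and meta to a large group. Compound 3 already gives 85 nM, in the range where compound 2 sits, so for compound 4 a step of a 1.2-fold lower number from compound 3 to compound 4 (0.08 log units; within the scatter) in this assay is expected rather than a repeat of the earlier large step. Compound 4 is estimated at 70 nM, between 30 nM and 180 nM.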

Compound 4, half-maximal inhibitory concentration: 550 nM
Estimate against measurement, compound 4: 7.9-fold (0.90 log units) below, outside the stated range (above it).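

In this assay, fluoro in place of hydrogen on an aromatic carbon does not carry over between cores as a single effect, and here it does not even keep its direction: the same change on two cores in this assay, a 150-fold lower number (2.18 log units; beyond the scatter) from compound 1 to compound 2 and a 6.5-fold higher number (0.81 log units; beyond the scatter) from compound 3 to compound 4, 990-fold (3.00 log units) apart, beyond the scatter of two such steps. On the core of compound 3, the fluoro entering next to the ring nitrogen gives a 6.5-fold higher number from compound 3 to compound 4 (0.81 log units; beyond the scatter), so the large gain of the earlier step cannot be assumed for a further fluoro in this series. These two steps do not show why they differ, as the core and the place of the entering fluoro both change between them, and two steps cannot separate these factors or give a rule for other positions.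

From the compounds shown here alone, it remains open whether a chloro, a methyl or an amine on the same carbon next to the ring nitrogen would follow the step seen with fluoro. The contribution of the ring nitrogen also stays open, as no listed pair differs in that one place.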